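This account rests on a few compounds, and the source may have more. Where it says the series, first, only, none or still open, it means among the compounds named here.

Measured compounds:
- compound 1, `CCCCCCCCCCCCNC(=O)[C@@H](NC(=O)c1nccc2ccccc12)[C@@H](C)O`, in a functional assay on A-431 cells (Homo sapiens) for cytotoxicity, read by MTT assay, with a stated time of 48 h (a lower number here means a stronger inhibitor, a higher number a weaker inhibitor), compound 1 gives 62800 nM
- compound 2, `CCCCCCCCCCCCCCNC(=O)[C@@H](NC(=O)c1ccccc1)[C@@H](C)O`, in this assay compound 2 gives 118000 nM

Compound 2 has the highest of the two numbers, which in this assay means the weaker effect on the cells. Its nearest neighbour is compound 1, whose number is lower, yet the gap between the two lies within the scatter of repeated measurements, so the two cannot be ranked against each other. Compound 1 and compound 2 differ in two places at once, so their values say nothing about either change on its own.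

Compound 3, `CCCCCCCCCCCCCCNC(=O)[C@@H](NC(=O)c1nccc2ccccc12)[C@@H](C)O`, is the next step: isoquinolin-1-yl in place of phenyl on a carbonyl carbon. It keeps the longer chain of compound 2 and takes the aromatic group of compound 1. Among the compounds with values here, since no single step of this kind has been measured, the expectation rests on the two neighbours. Because compound 1 with the same aromatic group gives 62800 nM, compound 3 is expected to come out close to that, and the estimated step from a 1.7-fold lower number from compound 2 to compound 3 (0.23 log units; within the scatter) is a slight drop that stays within the scatter. The estimate for compound 3 is 70000 nM, with a range from 25000 nM to 200000 nM.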

Compound 3, half-maximal inhibitory concentration: 23000 nM
The estimate for compound 3 lay 3.0-fold (0.48 log units) above the measured number; the whole stated range lies above it.
By their numbers in this assay, from the lowest: compound 3; then compounds 1 and 2 (each within the scatter of the next).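

Isoquinolin-1-yl in place of phenyl on a carbonyl carbon, with the chain unchanged, gives a 5.1-fold lower number from compound 2 to compound 3 (0.71 log units; beyond the scatter) in this assay, which shows that the aromatic group at this position affects the read-out, something the earlier pair, differing in two places at once, could not show. The added ethyl on a saturated chain carbon, with the isoquinolin-1-yl group unchanged, gives a 2.7-fold lower number from compound 1 to compound 3 (0.44 log units; beyond the scatter), so chain length also affects the read-out, and compound 3 is the strongest of the three in this assay. No measurement at hand explains either change.

The change in the aromatic group adds both a second ring and a ring nitrogen, so the compounds shown leave open which of the two matters, and a naphthyl group, with two rings of carbon only, or a pyridyl group, with a single ring holding a nitrogen, would help to separate them. They also leave open whether a longer chain would lower the number further or whether the trend stops at this length.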